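The source may hold more compounds than are shown below. What is called first, only, known or untested is meant among the compounds shown, and "the series" means these compounds.

Measured compounds:
Compound 1 `Cc1cc(C)cc(/C=C(\C(=O)c2ccc(Cl)cc2)S(=O)(=O)c2ccc(Br)cc2)c1` gives 10000 nM
Compound 2 `Cc1ccc(/C=C(\C(=O)c2ccc(Cl)cc2)S(=O)(=O)Cc2ccc(Cl)cc2Cl)s1` gives 10000 nM
Compound 3 `Cc1ccc(S/C(=C/c2ccc(Br)cc2)C(=O)c2ccc(Cl)cc2)cc1` gives 25000 nM

All three compounds were tested in a functional assay on DU-145 cells (Homo sapiens) for inhibition, read by trypan blue exclusion, with a stated time of 96 h; a higher number here means a weaker inhibitor of growth, a lower number a stronger inhibitor of growth. Compound 2 stands level with compound 1 at the digits shown, and together they hold the lowest of the three numbers; its nearest neighbour is compound 1, from which it does not differ within the scatter, and its furthest is compound 3, whose value is higher by a margin beyond the scatter. No pair among these three differs in only one place, so no single step can be read off the measured set.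

The piece follows the change from compound 2 to compound 4 `Cc1ccc(S(=O)(=O)/C(=C/c2ccc(C)s2)C(=O)c2ccc(Cl)cc2)cc1`, which has not yet been measured in this assay. The change is 4-methylphenyl in place of 2,4-dichlorobenzyl on a sulfonyl sulfur. Nothing in the measured set isolates the effect of the group on the sulfonyl sulfur, and all three measured values lie in the same weak region of this assay. For that reason compound 4 is expected to stay close to compound 2, with a step of a 1.2-fold higher number from compound 2 to compound 4 (0.08 log units; within the scatter) that is not expected to go beyond the scatter in either direction. Compound 4 is therefore estimated at 12000 nM, within a range from 5000 nM to 30000 nM.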

Compound 4, concentration for 50% growth inhibition: 50000 nM
Estimate against measurement, compound 4: 4.2-fold (0.62 log units) below, and the stated range ends below it.
By their numbers in this assay, from the lowest: compounds 1 and 2 (each within the scatter of the next); then compounds 3 and 4 (each within the scatter of the next).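

In this assay the group on the sulfonyl sulfur proves able to move the read-out, with 4-methylphenyl in place of 2,4-dichlorobenzyl giving a 5.0-fold higher number from compound 2 to compound 4 (0.70 log units; beyond the scatter), a step beyond the scatter. Among these compounds, the earlier compounds could not show this, as no two of them differed in only one place, and this pair is the first direct reading of a change at this position. The exchange replaces a group of 9 heavy atoms, two of them chlorine, with one of 7 heavy atoms, all carbon; each group has one six-membered aromatic ring, and neither has hydrogen-bond donors, acceptors or a net charge, and no measurement shown here explains the step.

A single pair cannot separate the loss of the two chlorine atoms from the change from a benzyl group to a phenyl group, which a plain benzyl or a 2,4-dichlorophenyl group on the sulfonyl sulfur would begin to tell apart. Also open, from the compounds shown here alone, is how this position would respond to a group of another kind, such as a longer alkyl chain, an amine or a carboxylic acid.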